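A few compounds are considered here, and "the series" means these few. Any claim that something is new, unique, unknown or untested is made for them only; others in the source may bear on it.

Measured compounds:
compound 1, `ClCc1cccc(Cn2cnc3nc(Cl)nc(Cl)c32)c1`: 1380 nM
compound 2, `ClCc1ccccc1Cn1cnc2nc(Cl)nc(Cl)c21`: "not determined" (no result reported)

In a functional assay on SNB-19 cells (Homo sapiens) for cytotoxicity, read by sulforhodamine B assay, with a stated time of 48 h (a lower number here means a stronger inhibitor of growth, a higher number a weaker inhibitor of growth), compound 1 gives 1380 nM. For compound 2 the outcome is "not determined" (no result reported), so compound 2 stands without a number, and compound 1 is the only anchor in the series. Compound 3, `ClCc1ccccc1Cn1cnc2ncnc(Cl)c21`, is the analogue of compound 2 with hydrogen in place of chloro on an aromatic carbon. Within the data shown here, no step between measured compounds covers this change, so its size in this assay has no precedent here; the expectation is a step beyond the scatter toward weaker growth inhibition rather than a gain. For compound 3 the value is estimated at 3500 nM, in the range 900 nM to 14000 nM.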

Compound 3, concentration for 50% growth inhibition: 7240 nM
For compound 3 the middle estimate is 2.1-fold (0.32 log units) below the measured one, and the stated range covers the measured number.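

No new step can be read, since compound 2 has no number to set against compound 3. The compounds shown leave open what replacing chloro with hydrogen does to growth inhibition. Nothing shown bears on a cause.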